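Swapping the para group on the aniline of a pyrimidine-dione core

The source may hold more compounds than are shown below. What is called first, only, known or untested is meant among the compounds shown, and "the series" means these compounds.

Three compounds share one core and differ only in the group hung from its amine. Compound 1, `O=C1C(Nc2ccc(OC(F)(F)F)cc2)=CC(=O)c2ncncc21`, compound 2, `O=C1C(NCc2ccc(F)cc2)=CC(=O)c2ncncc21`, and compound 3, `COc1ccc(NC2=CC(=O)c3ncncc3C2=O)cc1`, were each tested in a functional assay on MIA PaCa-2 cells (Homo sapiens) for cytotoxicity, read by MTT assay, with a stated time of 72 h; a lower number here means a stronger inhibitor, a higher number a weaker inhibitor. There compound 1 gives 1400 nM, compound 2 gives 1700 nM, and compound 3 gives 1900 nM. For the measured compounds named here, compound 3 thus has the highest of the three numbers, but the gaps to the other two are small: the only single change recorded, a 1.4-fold higher number from compound 1 to compound 3 (0.13 log units; within the scatter), stays within the scatter, and compound 2 sits closer still.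

Compound 4, `NS(=O)(=O)c1ccc(NC2=CC(=O)c3ncncc3C2=O)cc1`, is the next member. Relative to compound 3 it carries sulfamoyl in place of methoxy on an aromatic carbon, on the ring that sits para to a large group. Going by the values given here, no measured step shows what a sulfamoyl does here; the one recorded step, a 1.4-fold higher number from compound 1 to compound 3 (0.13 log units; within the scatter), concerns a different exchange on the same aromatic carbon and stayed within the scatter. With no pointer in either direction, the expectation is that compound 4 will land near compound 3, giving 2000 nM in this assay, with a range from 800 nM to 5000 nM; the step this implies, a 1.1-fold higher number from compound 3 to compound 4 (0.02 log units; within the scatter), is expected to fall within the scatter.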

Compound 4, half-maximal inhibitory concentration: > 10000 nM
Compound 4: a limit, no number (the forecaster's own chance of this, stated with the estimate: 5%); middle value at least 5.0-fold (0.69 log units) from the limit.
By their numbers in this assay, from the lowest: compounds 1, 2 and 3 (each within the scatter of the next). At a limit, above all of these: compound 4.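

Up to this point the group on this aromatic carbon could be exchanged, trifluoromethoxy for methoxy, without a change beyond the scatter, so the position looked tolerant of what sits there. Sulfamoyl is the first group here to move the read-out beyond the scatter, with an at least 5.2-fold higher number from compound 3 to compound 4 (0.72 log units; beyond the scatter) and an at least 7.1-fold higher number from compound 1 to compound 4 (0.85 log units; beyond the scatter), which shows that the choice of group at this place can matter a great deal for cytotoxicity. In this assay compound 4 gives > 10000 nM, a limit of the assay and not a number, so both steps give only a lower bound on the size of the change and the true size stays unknown: the limit of > 10000 nM in this assay, at which 1 of the 4 values shown sits.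

Sulfamoyl differs from methoxy in several ways at once, in heavy atoms, in hydrogen-bond donors and in hydrogen-bond acceptors, and the compounds shown do not tell which of these differences goes with the loss. A methyl sulfone, which has no hydrogen-bond donor, or a carboxylic acid or an amine on the same aromatic carbon would help to separate them.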